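Swapping the Aryl Amide for an Imine Group

This account rests on a few compounds, and the source may have more. Where it says the series, first, only, none or still open, it means among the compounds named here.

Compound 1 `N#CC1=C(N)N(c2ccc(S(N)(=O)=O)cc2)C2=C(C(=O)CCC2)C1c1ccc(Cl)cc1Cl` — 50%
Compound 2 `CC(Cl)CC(=O)NC1=C(C#N)C(c2ccc(Cl)cc2Cl)C2=C(CCCC2=O)N1c1ccc(S(N)(=O)=O)cc1` — 50%
Compound 3 `Cc1ccc(C(=O)NC2=C(C#N)C(c3ccc(Cl)cc3Cl)C3=C(CCCC3=O)N2c2ccc(S(N)(=O)=O)cc2)cc1` — 30%

In a functional assay on Ehrlich cells (Mus musculus) for cytotoxicity, read by trypan blue exclusion, with a stated time of 2 h, tested at 25 ug/mL (on this read-out higher numbers stand for a stronger effect at the one concentration tested and lower numbers for a weaker effect), compound 3 stands lowest of the three measured numbers: a number 20 percentage points lower from compound 1 to compound 3 (beyond the scatter) and a number 20 percentage points lower from compound 2 to compound 3 (beyond the scatter), while no change at the digits printed from compound 1 to compound 2 (within the scatter). Compound 4 `CN(C)c1ccc(/C=N/C2=C(C#N)C(c3ccc(Cl)cc3Cl)C3=C(CCCC3=O)N2c2ccc(S(N)(=O)=O)cc2)cc1` has not been measured. It differs from compound 3 in one place: a group of 11 heavy atoms (9 carbon, 2 nitrogen; one six-membered aromatic ring of carbon only) in place of a group of 10 heavy atoms (8 carbon, 1 nitrogen, 1 oxygen; one six-membered aromatic ring of carbon only), on a double-bonded ring carbon. For the measured compounds named here, no measured step replaces an amide by such an imine group, so the measured steps bear on this change only loosely. A small rise is expected because a number 20 percentage points lower from compound 1 to compound 3 (beyond the scatter) came with adding the aryl amide that now leaves. The expected step is a number 10 percentage points higher from compound 3 to compound 4 (within the scatter), though no change beyond the scatter is nearly as plausible. Compound 4 is estimated at 40%, in a range from 20% to 60%.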

Compound 4, a percentage reported as activity, at one concentration (the size of the read-out at that concentration, not a potency): 30%
Beside the measured number, compound 4's estimate is 10 percentage points above it, and the stated range covers the measured number.
By their numbers in this assay, from the lowest: compounds 3 and 4 (each within the scatter of the next); then compounds 1 and 2 (each within the scatter of the next).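

Replacing the aryl amide with the imine group on this ring carbon gives no change at the digits printed from compound 3 to compound 4 (within the scatter) in this assay even though the amide hydrogen is lost. Both a number 20 percentage points lower from compound 2 to compound 4 (beyond the scatter) and a number 20 percentage points lower from compound 1 to compound 4 (beyond the scatter) place the imine group with the aryl amide, so among the compounds shown the two groups carrying an aromatic ring give the lower numbers. Nothing available explains this result.

On these data alone, it remains open whether the aromatic ring itself goes with the lower number. An imine bearing a plain ethyl chain could help to settle that.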